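Trifluoromethoxy for fluoro on a second core

This account rests on a few compounds, and the source may have more. Where it says the series, first, only, none or still open, it means among the compounds named here.

Measured compounds:
compound 1, `Cc1ccc([C@@H]2C[C@H](O)Cc3cc(F)ccc3N2)o1`, 823000 nM
compound 2, `Cc1ccc([C@@H]2C[C@H](O)Cc3cc(OC(F)(F)F)ccc3N2)o1`, 82100 nM
compound 3, `O[C@@H]1Cc2cc(F)ccc2N[C@H](c2ccoc2)C1`, 1040000 nM

Of the compounds shown here, three have been tested in an ADME assay on Vero cells (Chlorocebus sabaeus) for cytotoxicity; on this read-out lower numbers stand for higher toxicity in this test and higher numbers for lower toxicity in this test. Compound 1, `Cc1ccc([C@@H]2C[C@H](O)Cc3cc(F)ccc3N2)o1`, gives 823000 nM in this assay. Compound 2, `Cc1ccc([C@@H]2C[C@H](O)Cc3cc(OC(F)(F)F)ccc3N2)o1`, gives 82100 nM. Compound 3, `O[C@@H]1Cc2cc(F)ccc2N[C@H](c2ccoc2)C1`, gives 1040000 nM.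

Compound 1 and compound 2 differ in one place: trifluoromethoxy in place of fluoro on an aromatic carbon. This change made a step of a 10-fold lower number from compound 1 to compound 2 (1.00 log units; beyond the scatter). Compound 1 and compound 3 differ in the group on the seven-membered ring: furan-3-yl in place of 5-methylfuran-2-yl on a saturated ring carbon. The step between them, a 1.3-fold higher number from compound 1 to compound 3 (0.10 log units; within the scatter), lies within the scatter, so compound 1 and compound 3 cannot be told apart in this assay.

Compound 4, `O[C@@H]1Cc2cc(OC(F)(F)F)ccc2N[C@H](c2ccoc2)C1`, has not yet been measured. It differs from compound 3 in one place: trifluoromethoxy in place of fluoro on an aromatic carbon. This is the same change, at the same place, as the one from compound 1 to compound 2; it occurs twice among the compounds shown. Within the data shown here, the only guide is that single step. Because the change from compound 1 to compound 2 gave a 10-fold lower number from compound 1 to compound 2 (1.00 log units; beyond the scatter), and because compound 3 gives 1040000 nM close to the number of compound 1, a step of about the same size is expected from compound 3 to compound 4, namely a 10-fold lower number from compound 3 to compound 4 (1.00 log units; beyond the scatter). On that basis compound 4 is estimated to give 104000 nM in this assay, expected to fall between 40000 nM and 300000 nM.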

Compound 4, half-maximal cytotoxic concentration: 95400 nM
The estimate for compound 4 lay 1.1-fold (0.04 log units) above the measured number; the range from low to high includes it.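

In this assay, trifluoromethoxy in place of fluoro on the core of compound 3 gave an 11-fold lower number from compound 3 to compound 4 (1.04 log units; beyond the scatter), and this step matches the one seen earlier on the core of compound 1: the same change on two cores in this assay, a 10-fold lower number (1.00 log units; beyond the scatter) from compound 1 to compound 2 and an 11-fold lower number (1.04 log units; beyond the scatter) from compound 3 to compound 4, 1.1-fold (0.04 log units) apart, within the scatter of two such steps

The furan change agrees with this picture, since furan-3-yl in place of 5-methylfuran-2-yl gave a 1.2-fold higher number from compound 2 to compound 4 (0.07 log units; within the scatter), a step that stays within the scatter with trifluoromethoxy on the aromatic carbon, just as it did with fluoro: the same change on two cores in this assay, a 1.3-fold higher number (0.10 log units; within the scatter) from compound 1 to compound 3 and a 1.2-fold higher number (0.07 log units; within the scatter) from compound 2 to compound 4, 1.1-fold (0.04 log units) apart, within the scatter of two such steps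

Across these four compounds, then, the trifluoromethoxy step carries over from one core to the other with its size intact, but the two cores differ only in their furan group, so this shows nothing about cores that differ more widely, and the numbers alone do not explain why the step occurs.

The compounds shown leave open whether chloro, methoxy or trifluoromethyl on that aromatic carbon would give a step like this one, or whether it belongs to trifluoromethoxy alone. They also leave open whether the step would survive with a phenyl or thiophene ring in place of the furan, or with an amine in place of the hydroxyl group.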